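Benzyl thioethers on a shared core: pyridyl to methylphenyl

The source may hold more compounds than are shown below. What is called first, only, known or untested is meant among the compounds shown, and "the series" means these compounds.

Compound 1 `Cc1cc(=O)oc2cc(SC3CCOC3=O)ccc12`: > 36100 nM
Compound 2 `Cc1cc(=O)oc2cc(SCc3ccncc3)ccc12`: > 35200 nM

Both values are limits of a functional assay on DU-145 cells (Homo sapiens) for antiproliferative activity, read by sulforhodamine B assay, with a stated time of 72 h (a lower number here means a stronger inhibitor of growth, a higher number a weaker inhibitor of growth), and not numbers. Compound 1 sits at the limit (the limit of > 36100 nM in this assay, at which 1 of the 2 values shown sits). Compound 2 sits at the limit (the limit of > 35200 nM in this assay, at which 1 of the 2 values shown sits). Going by the values given here, neither compound therefore shows measurable growth inhibition, and no step between them can be sized. Compound 3 `Cc1cccc(CSc2ccc3c(C)cc(=O)oc3c2)c1` is not yet measured; it differs from compound 2 by 3-methylphenyl in place of pyridin-4-yl on a saturated chain carbon bound to a sulfur. Among the compounds with values here, with no measured step in the set, the expected step from compound 2 to compound 3 in this assay is an at least 1.1-fold lower number from compound 2 to compound 3 (0.06 log units; that floor lies within the scatter), most likely none beyond the scatter, with a fair chance of another limit. Compound 3 is estimated at 30000 nM, range 10000 nM to 100000 nM.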

Compound 3, concentration for 50% growth inhibition: > 33700 nM
Compound 3: a limit, no number; the forecaster's own chance of this, stated with the estimate: 60%; at least 1.1-fold (0.05 log units) between middle value and limit.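

Going by these compounds alone, compound 2 and compound 3 both stand as limits, not numbers; no step between them can be read. The compounds shown leave open whether any group on this saturated chain carbon gives measurable growth inhibition.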